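A few compounds are considered here, and "the series" means these few. Any claim that something is new, unique, unknown or untested is made for them only; others in the source may bear on it.

Compound 2 `CCn1c(C(=O)NCCC(=O)OC)ccc1C(CC)(CC)c1ccc(OCS(=O)(=O)c2ccccc2)c(C)c1` is the point of departure here. In a functional assay on MCF7 cells (Homo sapiens) for antiproliferative activity, read by MTT assay, with a stated time of 24 h (a higher number here means a weaker inhibitor, a lower number a stronger inhibitor), compound 2 gives only a limit of the assay, > 50000 nM, namely (the limit of > 50000 nM in this assay, at which 1 of the 3 values shown sits). Its companions are compound 1 `CCn1c(C(=O)N[C@@H](C)C(=O)OC)ccc1C(CC)(CC)c1ccc(OCS(=O)(=O)c2ccccc2)c(C)c1`, which in this assay gives 43700 nM, and compound 3 `CCn1c(C(=O)N[C@@H](C)C(=O)O)ccc1C(CC)(CC)c1ccc(OCS(=O)(=O)c2ccccc2)c(C)c1`, which gives 35500 nM. Among the measured steps, an at least 1.1-fold higher number from compound 1 to compound 2 (0.05 log units; that floor lies within the scatter) and a 1.2-fold lower number from compound 1 to compound 3 (0.09 log units; within the scatter), while an at least 1.4-fold lower number from compound 2 to compound 3 (0.14 log units; that floor lies within the scatter). Compound 4 `CCn1c(C(=O)N[C@H](C)C(=O)O)ccc1C(CC)(CC)c1ccc(OCS(=O)(=O)c2ccccc2)c(C)c1` carries the same change as compound 3, (1-carboxyethyl in place of 2-(methoxycarbonyl)ethyl on an amide-type nitrogen), with the opposite configuration at the defined stereocentre. For the measured compounds named here, because an at least 1.4-fold lower number from compound 2 to compound 3 (0.14 log units; that floor lies within the scatter) is the one measured step of this kind, compound 4 is expected to give 40000 nM in this assay, within 20000 nM to 80000 nM, which is an at least 1.2-fold lower number from compound 2 to compound 4 (0.09 log units; that floor lies within the scatter).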

Compound 4, half-maximal inhibitory concentration: > 50000 nM
Compound 4 ended at the assay's limit; the forecaster's own chance of this, stated with the estimate: 35%; middle value at least 1.2-fold (0.09 log units) from the limit.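

In this assay compound 4 gives > 50000 nM, which is a limit and not a number. Inverting the stereocentre of the 1-carboxyethyl group on the amide-type nitrogen gives the first reading of configuration at this position (an at least 1.4-fold higher number from compound 3 to compound 4 (0.14 log units; that floor lies within the scatter)), and its floor does not pass the scatter: the fact that compounds 3 and 4 differ only in the configuration as drawn. The floor of the other readable step (an at least 1.1-fold higher number from compound 1 to compound 4 (0.05 log units; that floor lies within the scatter)) also stays within the scatter, while the step between the two limit compounds cannot be read.

From the compounds shown here alone, the true size of the configuration step stays open, since only its floor is known. So does the effect of an amine or a longer carboxylic acid chain on this amide-type nitrogen.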